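Catechol replacement on the arylidene cyclohexanone series

This account rests on a few compounds, and the source may have more. Where it says the series, first, only, none or still open, it means among the compounds named here.

Compound 1 `COc1cccc(/C=C2\CCC/C(=C\c3ccc(Cl)cc3)C2=O)c1OC` gives 10300 nM in a functional assay on MCF7 cells (Homo sapiens) for cytotoxicity, read by MTT assay, with a stated time of 72 h (on this read-out higher numbers stand for weaker inhibition and lower numbers for stronger inhibition), and compound 2 `COc1cccc(/C=C2\CCC/C(=C\c3ccccc3Br)C2=O)c1OC` gives 9700 nM; the step of a 1.1-fold lower number from compound 1 to compound 2 (0.03 log units; within the scatter) shows that trading one halogenated phenyl for another left the read-out unchanged. Compound 3 `COc1ccc(/C=C2\CCC/C(=C\c3cccc(Cl)c3)C2=O)cc1OC` gives 6000 nM, and both compound 1 and compound 2 lie within the scatter of it, so no order among the three can be drawn. Compound 4 `COc1ccc(/C=C2\CCC/C(=C\c3ccc(O)c(O)c3)C2=O)cc1OC` differs from compound 3 by 3,4-dihydroxyphenyl in place of 3-chlorophenyl on a double-bonded chain carbon bound to a double-bonded ring carbon. Among the compounds with values here, no measured step involves a hydroxylated aryl group, so the only bearing evidence is the flat halogen swap from compound 1 to compound 2. The step of a 1.3-fold lower number from compound 3 to compound 4 (0.12 log units; within the scatter) is therefore expected to stay within the scatter, and compound 4 is estimated at 4500 nM, with a range of 1500 nM to 15000 nM.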

Compound 4, half-maximal inhibitory concentration: 14400 nM
Compound 4: middle estimate off by 3.2-fold (0.51 log units), on the low side, within the range that was stated.
By their numbers in this assay, from the lowest: compounds 3, 2, 1 and 4 (each within the scatter of the next, the first and the last beyond it).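

In this assay the change to 3,4-dihydroxyphenyl gives a 2.4-fold higher number from compound 3 to compound 4 (0.38 log units; beyond the scatter) and so moves toward weaker inhibition, unlike the flat halogen swap. The position on a double-bonded chain carbon bound to a double-bonded ring carbon therefore responds to the aryl group, at least for this replacement of 3-chlorophenyl. No supporting measurement bears on the reason for this shift.

Still open, going by these compounds, is whether both hydroxyl groups are needed for this step. A phenyl carrying one hydroxyl, an amine or a carboxylic acid would help separate these possibilities.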